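This account rests on a few compounds, and the source may have more. Where it says the series, first, only, none or still open, it means among the compounds named here.

Series of amides on a shared core. Compound 1 `CCOC(=O)CCCCCOc1cccc(CN(C(=O)c2ccc(-c3cccc(NC(C)=O)c3)cc2)C(C)C)c1` carries an acetamido group. In an ADME assay on BJ cells (Homo sapiens) for cytotoxicity, read by CellTiter-Glo and resazurin assay, with a stated time of 72 h (a higher number here means that more compound is needed for the effect, a lower number that less compound is needed), compound 1 gives only a limit, > 26000 nM. Compound 2 `CCOC(=O)CCCCCOc1cccc(CN(C(=O)c2ccc(-c3cccc(-c4ccccc4)c3)cc2)C(C)C)c1` carries a phenyl in place of the acetamido on an aromatic carbon. In this assay compound 2 likewise sits at a limit, > 26000 nM. Compound 3 `CCOC(=O)CCCCCOc1cccc(CN(C(=O)c2ccc(-c3ccco3)cc2)C(C)C)c1` carries a furan-2-yl on an aromatic carbon. In this assay compound 3 also gives a limit, > 26000 nM. The steps a step that the two limits leave unreadable from compound 1 to compound 2, a step that the two limits leave unreadable from compound 1 to compound 3 and a step that the two limits leave unreadable from compound 2 to compound 3 cannot be sized because of the limit of > 26000 nM in this assay, at which 3 of the 3 values shown sit. Compound 3 therefore stands with the other two measured compounds at the limit, with no number of its own.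

Compound 4 `CCOC(=O)CCCCCOc1cccc(CN(C(=O)c2ccc(-c3ccc(C(C)=O)s3)cc2)C(C)C)c1` is not yet measured. The change is 5-acetylthiophen-2-yl in place of furan-2-yl on an aromatic carbon. The three measured steps bear on it only in that every exchange of the group on that aromatic carbon has left the value at the limit; none gives a readable size. The expected step is a step that the limit leaves unreadable from compound 3 to compound 4, that is, no readable change in this assay. Compound 4 is estimated at 30000 nM in this assay, with a range from 12000 nM to 80000 nM, most likely reported again as a limit.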

Compound 4, half-maximal effective concentration: > 26000 nM
Compound 4 ended at the assay's limit; the forecaster's own chance of this, stated with the estimate: 80%; the middle value is on the limit's open side.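

No new step can be read for compound 4 against compound 1, compound 2 or compound 3, because all four remain at one limit: (the limit of > 26000 nM in this assay, at which 4 of the 4 values shown sit). The compounds shown leave open whether any exchange of the group on that aromatic carbon alters the read-out in this assay, and where any half-maximal concentration lies.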